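This account rests on a few compounds, and the source may have more. Where it says the series, first, only, none or still open, it means among the compounds named here.

Measured compounds:
- Compound 1, `CC/C(=C(/c1ccc(/C=C/C(=O)O)cc1)c1ccc2[nH]ncc2c1)c1ccccc1`: 7.2 nM
- Compound 2, `CC/C(=C(/c1ccc(/C=C/C(=O)O)cc1)c1ccc2c(cnn2C)c1)c1ccccc1`: 300 nM
- Compound 3, `CC/C(=C(/c1ccc(/C=C/C(=O)O)cc1)c1ccc(-c2cn[nH]c2)cc1)c1ccccc1`: 40 nM

These three compounds were compared in a functional assay on MCF7 cells (Homo sapiens) for antiproliferative activity, read by CellTiter-Glo, with a stated time of 5 days; on this read-out higher numbers stand for weaker inhibition and lower numbers for stronger inhibition. Compound 1 gives 7.2 nM, and compound 2, which carries methyl in place of hydrogen on an aromatic nitrogen, gives 300 nM; the step of a 42-fold higher number from compound 1 to compound 2 (1.62 log units; beyond the scatter) is the one measured effect of this change. Compound 3 gives 40 nM; the difference between the core of compound 3 and the core of compound 1 is not broken down here, and their two values show compound 3 at the higher number.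

Compound 4, `CC/C(=C(/c1ccc(/C=C/C(=O)O)cc1)c1ccc(-c2cnn(C)c2)cc1)c1ccccc1`, has not yet been measured. It differs from compound 3 by methyl in place of hydrogen on an aromatic nitrogen. For the measured compounds named here, this is the same kind of change as the one from compound 1 to compound 2, though not the same: in compound 1 the five-membered aromatic ring is part of a fused or bridged system of two rings, whereas in compound 3 the ring nitrogen lies two ring bonds from the ring atom that bears a large group.

Because the step of a 42-fold higher number from compound 1 to compound 2 (1.62 log units; beyond the scatter) was large, a weakening is expected for compound 4 as well, though with a single precedent on a different core the size is uncertain. Compound 4 is expected to reach about 600 nM in this assay, a step of a 15-fold higher number from compound 3 to compound 4 (1.18 log units; beyond the scatter), with a plausible range from 150 nM to 2500 nM.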

Compound 4, half-maximal inhibitory concentration: 80 nM
Compound 4: the middle estimate sits 7.5-fold (0.88 log units) above what was measured; measured number below the stated range.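

In this assay, methyl in place of hydrogen on an aromatic nitrogen does not carry the same size of effect from one core to the other, and the two steps differ: the same change on two cores in this assay, a 42-fold higher number (1.62 log units; beyond the scatter) from compound 1 to compound 2 and a 2.0-fold higher number (0.30 log units; within the scatter) from compound 3 to compound 4, 21-fold (1.32 log units) apart, beyond the scatter of two such steps

On the core that bears the 1H-pyrazol-4-yl group, the change gives a 2.0-fold higher number from compound 3 to compound 4 (0.30 log units; within the scatter), so this pair cannot be told apart in this read-out, whereas on the core of compound 1 it gives a 42-fold higher number from compound 1 to compound 2 (1.62 log units; beyond the scatter). This shows that the large weakening seen on one core cannot be assumed on the other, but two pairs do not show why the steps differ, nor what the change would do on any further core.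

The compounds shown leave open whether an ethyl group or a longer chain on the same aromatic nitrogen would follow the large step or the small one on each core. All four compounds also share the carboxylic acid, so they give no indication of how an amide in its place would affect either the values or the gap between the two steps.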